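Adding a 4-bromobenzyl group to an inactive compound

The compounds below may be only part of what the source reports. "The series", "measured", "known", "first", "only" and "open" are said of these compounds alone.

Compound 1 `CN1C(=O)C(O)(Cc2nnn[nH]2)c2cc(F)ccc21`: > 100000 nM
Compound 2 `CN1C(=O)C(O)(Cc2nnn[nH]2)c2cc(Cl)ccc21`: > 100000 nM

Neither compound has a true number in a functional assay on BT-549 cells (Homo sapiens) for antiproliferative activity, read by MTT assay, with a stated time of 48 h; a lower number here means a stronger inhibitor, a higher number a weaker inhibitor. There, compound 2 gives > 100000 nM, which is a limit only. Compound 1 is also known only as a limit, and the record so far reads: the limit of > 100000 nM in this assay, at which 2 of the 2 values shown sit.

Compound 3 `O=C1N(Cc2ccc(Br)cc2)c2ccc(Cl)cc2C1(O)Cc1nnn[nH]1` differs from compound 2 in one place: 4-bromophenyl in place of hydrogen on a saturated chain carbon bound to an amide-type nitrogen in a ring. Put another way, this is methyl to 4-bromobenzyl, on a saturated chain carbon bound to an amide-type nitrogen in a ring.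

Going by the values given here, the only measured step is a step that the two limits leave unreadable from compound 1 to compound 2, with chloro in place of fluoro on an aromatic carbon. It offers no size to carry over, so any forecast is a cautious guess. A move toward stronger inhibition in this assay is expected, though compound 3 may also stay at the limit.

The expected change is an at least 2.5-fold lower number from compound 2 to compound 3 (0.39 log units; beyond the scatter).

For compound 3 the estimated value is 40000 nM, with an expected range of 8000 nM to 100000 nM.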

Compound 3, half-maximal inhibitory concentration: 74500 nM
Compound 3: the middle estimate sits 1.9-fold (0.27 log units) below what was measured, within the range that was stated.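

Methyl to 4-bromobenzyl, on a saturated chain carbon bound to an amide-type nitrogen in a ring, yields the first true number in this assay: compound 3 gives 74500 nM. The change reads as an at least 1.3-fold lower number from compound 2 to compound 3 (0.12 log units; that floor lies within the scatter), so this floor alone does not show a change beyond the usual scatter, although the real difference could be larger. Compound 3 is the only compound shown that is not held at the limit of the assay, so this position is the first place in the series where a change has produced a measurable value: the limit of > 100000 nM in this assay, at which 2 of the 3 values shown sit.

On these data alone, it remains open whether a plain benzyl group, a 4-methoxybenzyl group or a longer chain at this position would also give a true number. As far as these compounds go, it is also open whether 4-bromobenzyl would do the same with fluoro in place of chloro on the aromatic carbon.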